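The compounds below may be only part of what the source reports. "The series", "measured", "known", "first", "only" and "open" are said of these compounds alone.

- Compound 1 `CC[C@@H](Nc1c(C#N)c(-c2ccc(-c3cccc(Cl)c3OC)cc2)nc2cnccc12)C(N)=O`: 3.1
- Compound 2 `CC[C@@H](Nc1c(C#N)c(-c2ccc(Br)cc2)nc2cnccc12)C(N)=O`: 2.2

In a physicochemical assay for lipophilicity, read by HPLC, at pH 7.5 (on this read-out lower numbers stand for lower lipophilicity and higher numbers for higher lipophilicity), compound 2 has the lower of the two numbers, at 2.2. The next molecule, compound 3 `CC[C@@H](Nc1c(C#N)c(-c2ccc(-c3ccccc3Cl)cc2)nc2cnccc12)C(N)=O`, changes compound 2 in one place: 2-chlorophenyl in place of bromo on an aromatic carbon. In words, 2-chlorophenyl stands in place of bromo on an aromatic carbon.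

Within the data shown here, one measured step bears on this: a number 0.90 log units lower from compound 1 to compound 2 (beyond the scatter), with bromo in place of 3-chloro-2-methoxyphenyl. The new change runs the opposite way, from bromo back to a substituted phenyl, though without the methoxy. Compound 1, at 3.1, therefore serves as the guide, and a rise of similar size is expected. The expected step is a number 0.80 log units higher from compound 2 to compound 3 (beyond the scatter). For compound 3 the estimated value is 3, with an expected range from 2.6 to 3.4.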

Compound 3, distribution coefficient: 2.9
For compound 3 the middle estimate is 0.10 log units above the measured one, and the stated range covers the measured number.
By their numbers in this assay, from the lowest: compound 2; then compounds 3 and 1 (each within the scatter of the next).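

In this assay, putting 2-chlorophenyl in place of bromo on this aromatic carbon gives a number 0.70 log units higher from compound 2 to compound 3 (beyond the scatter). The rise seen with compound 1 is therefore not tied to one particular substituted phenyl group. A second one, carrying a single chlorine and no methoxy, also stands clearly apart from the bromo compound. Going the other way, 2-chlorophenyl in place of 3-chloro-2-methoxyphenyl gives a number 0.20 log units lower from compound 1 to compound 3 (within the scatter), so on this read-out these two groups cannot be told apart, and the methoxy and the position of the chlorine show no separate effect here.

On these data alone, how this position would read with a plain phenyl, or with a phenyl carrying an amine or a carboxylic acid, stays open. Nothing measured here gives a reason for these numbers.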